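The source may hold more compounds than are shown below. What is called first, only, known or untested is meant among the compounds shown, and "the series" means these compounds.

Measured so far:
compound 1, `CC[C@@H](CCn1cncn1)c1ccccc1`: 91.2 ug/mL
compound 2, `CC[C@@H](CCn1cncn1)c1ccc(OC)cc1`: 115 ug/mL

Both numbers come from an ADME assay on RD cells (Homo sapiens) for cytotoxicity, read by MTT assay, with a stated time of 3 days; a higher number here means that more compound is tolerated, a lower number that less compound is tolerated. Going by the values given here, compound 2 and compound 1 lie within the scatter of each other, as the only measured step shows: a 1.3-fold higher number from compound 1 to compound 2 (0.10 log units; within the scatter). So the methoxy added in compound 2 leaves the tolerated concentration essentially unchanged.

Compound 3, `COc1ccc([C@H](CCn2cncn2)Cc2ccccc2)cc1`, has not been measured. It differs from compound 2 in one place: phenyl in place of methyl on a saturated chain carbon, two bonds along the chain from an aromatic carbon. No measured step matches this change; the single step shown concerns an aromatic substituent, not the chain, and was itself within the scatter. There is therefore no direct basis for expecting a step beyond the scatter in this assay in either direction. Compound 3 is expected to give 70 ug/mL, with a range of 30 ug/mL to 150 ug/mL, an expected step of a 1.6-fold lower number from compound 2 to compound 3 (0.22 log units; within the scatter) that stays within the scatter.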

Compound 3, half-maximal cytotoxic concentration: 66 ug/mL
The estimate for compound 3 lay 1.1-fold (0.03 log units) above the measured number; the measured number falls inside the stated range.
By their numbers in this assay, from the lowest: compounds 3, 1 and 2 (each within the scatter of the next).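

In this assay, exchanging the methyl for a phenyl gives a 1.7-fold lower number from compound 2 to compound 3 (0.24 log units; within the scatter), a step that stays within the usual variation between repeats. The earlier compounds shown here showed only a change on an aromatic carbon; this result adds that the chain position can carry a whole six-membered aromatic ring with no step beyond the scatter. Nothing available explains this outcome.

The compounds shown leave open how an amine, a carboxylic acid or a longer chain on this same chain carbon would read in this assay. They also leave open what the methoxy contributes once phenyl is present, since no compound shown carries phenyl on the chain without it.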